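The source may report more compounds than this note shows. Statements on the series, on what has been measured and on what is new or still open speak of the compounds shown alone.

Three amides on a shared core have been run in a functional assay on HeLa cells (Homo sapiens) for antiproliferative activity, read by CCK-8 assay, with a stated time of 72 h; a higher number here means a weaker inhibitor, a lower number a stronger inhibitor. Compound 1 `O=C(Nc1cccc(-c2oc3cc(-c4ccc(F)cc4)ccc3c(=O)c2O)c1)c1ccccc1F` gives 5630 nM, compound 2 `O=C(Nc1cccc(-c2oc3cc(-c4ccc(F)cc4)ccc3c(=O)c2O)c1)c1ccc(C(F)(F)F)cc1` gives 17400 nM, and compound 3 `O=C(Nc1cccc(-c2oc3cc(-c4ccc(F)cc4)ccc3c(=O)c2O)c1)c1ccc(Br)cc1` gives 9740 nM. Compound 3 holds the middle of the three numbers, within the scatter of both others: a 1.7-fold higher number from compound 1 to compound 3 (0.24 log units; within the scatter) and a 1.8-fold lower number from compound 2 to compound 3 (0.25 log units; within the scatter), whereas a 3.1-fold higher number from compound 1 to compound 2 (0.49 log units; beyond the scatter). Compound 4 `Cc1cc(C)cc(C(=O)Nc2cccc(-c3oc4cc(-c5ccc(F)cc5)ccc4c(=O)c3O)c2)c1` differs from compound 3 by 3,5-dimethylphenyl in place of 4-bromophenyl on a carbonyl carbon. The steps that exchange the group on the carbonyl carbon bear on this: two stayed within the scatter and one was modest. For the measured compounds named here, the 3,5-dimethylphenyl group has no precedent, so no step beyond the scatter is expected in this assay in either direction. Compound 4 is expected at 9000 nM, with a range of 4000 nM to 25000 nM. This expectation means a step of a 1.1-fold lower number from compound 3 to compound 4 (0.03 log units; within the scatter).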

Compound 4, half-maximal inhibitory concentration: 5540 nM
The estimate for compound 4 lay 1.6-fold (0.21 log units) above the measured number; the measured number falls inside the stated range.
By their numbers in this assay, from the lowest: compounds 4, 1, 3 and 2 (each within the scatter of the next, the first and the last beyond it).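

In this assay, 3,5-dimethylphenyl on the carbonyl carbon is accommodated, with no separation from the 4-bromophenyl amide (a 1.8-fold lower number from compound 3 to compound 4 (0.25 log units; within the scatter)) or the 2-fluorophenyl amide (a 1.0-fold lower number from compound 1 to compound 4 (0.01 log units; within the scatter)). Only the 4-(trifluoromethyl)phenyl amide stands apart from it (a 3.1-fold lower number from compound 2 to compound 4 (0.50 log units; beyond the scatter)), matching the gap already seen between that amide and compound 1. Nothing available explains these differences. On these data alone, it remains open whether a non-aromatic group such as cyclohexyl, or a pyridine ring, would hold these numbers on the carbonyl carbon.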